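Aminoamino in place of methylsulfanyl on the shared core

The source may hold more compounds than are shown below. What is called first, only, known or untested is meant among the compounds shown, and "the series" means these compounds.

Measured in a functional assay, with a stated time of 150 min; a higher number here means a weaker inhibitor, a lower number a stronger inhibitor:
compound 1, `CSc1nc(-c2ccco2)c(C#N)c(=O)n1C`, gives 108 ug/mL
compound 2, `COc1cccc(-c2nc(NN)n(C)c(=O)c2C#N)c1OC`, gives 54 ug/mL
compound 3, `Cn1c(NN)nc(-c2ccccc2O)c(C#N)c1=O`, gives 46 ug/mL

Compound 1 has the highest of the three numbers in this assay; compound 2 sits within the scatter of compound 1, while compound 3 lies beyond it with a lower number. Among the compounds with values here, no two measured compounds differ in one place only, so no single step can be read off. Compound 4, `Cn1c(NN)nc(-c2ccco2)c(C#N)c1=O`, differs from compound 1 by aminoamino in place of methylsulfanyl on an aromatic carbon. Compounds 2 and 3 also carry aminoamino, and compound 3 gives 46 ug/mL against compound 1, so a moderate drop is expected in this assay: the step from compound 1 to compound 4 is estimated at a 2.0-fold lower number from compound 1 to compound 4 (0.29 log units; within the scatter). Compound 4 is expected to give 55 ug/mL, within 25 ug/mL to 120 ug/mL.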

Compound 4, half-maximal inhibitory concentration: 65 ug/mL
Compound 4: middle estimate off by 1.2-fold (0.07 log units), on the low side, within the range that was stated.
By their numbers in this assay, from the lowest: compounds 3, 2, 4 and 1 (each within the scatter of the next, the first and the last beyond it).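

Working from the one-place comparison in this series, in this assay aminoamino in place of methylsulfanyl on an aromatic carbon gives a 1.7-fold lower number from compound 1 to compound 4 (0.22 log units; within the scatter), with the furan-2-yl group unchanged. At this position, between two ring nitrogen atoms, the two groups therefore cannot be told apart in this read-out. No supporting data bear on this result.

As far as these compounds go, whether the exchange gives a similar step with a group other than furan-2-yl remains open. So does whether a dimethylamino or ethylsulfanyl group at this position would move the number beyond the scatter.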